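The source may hold more compounds than are shown below. What is called first, only, known or untested is meant among the compounds shown, and "the series" means these compounds.

In a functional assay on DLD-1 cells (Homo sapiens) for cytotoxicity, read by colorimetric assay and MTT assay, with a stated time of 3 days, tested at 20 uM (a lower number here means a stronger effect, a higher number a weaker effect of the compound at the concentration tested), compound 1 `COc1ccc(-c2nc(-c3ccccc3)c(-c3ccc4c(c3)NC(=O)CO4)[nH]2)cc1` gives 19.1%, the lowest number of the three measured compounds and therefore the strongest effect among them. Compound 2 `COc1ccc(-n2cc(-c3ccccc3)c(-c3ccc4c(c3)NC(=O)CO4)n2)cc1` gives 35.6%, and compound 3 `O=C1COc2ccc(-c3nn(-c4ccccc4)cc3-c3ccccc3)cc2N1` gives 47.7%. Compounds 2 and 3 share a core that is different from the core of compound 1, and they differ from each other only by hydrogen in place of methoxy on an aromatic carbon.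

Compound 4 `O=C1COc2ccc(-c3[nH]c(-c4ccc(Cl)cc4Cl)nc3-c3ccccc3)cc2N1` has not yet been measured. Compared with compound 1 it carries 2,4-dichlorophenyl in place of 4-methoxyphenyl on an aromatic carbon. Within the data shown here, no measured step swaps one whole ring for another, so the only guide is the step from compound 2 to compound 3, where the methoxy group is also lost. A modest weakening is expected for compound 4 because a number 12.1 percentage points higher from compound 2 to compound 3 (beyond the scatter) pointed upward, while the two chlorines add an unknown of their own. For compound 4 the expected result is 30%, with a range from 15% to 50%. The expected step is therefore a number 10.9 percentage points higher from compound 1 to compound 4 (beyond the scatter).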

Compound 4, a percentage reported as activity, at one concentration (the size of the read-out at that concentration, not a potency): 61.9%
Beside the measured number, compound 4's estimate is 31.9 percentage points below it, outside the stated range (above it).
By their numbers in this assay, from the lowest: compound 1; then compound 2; then compound 3; then compound 4.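

In this assay, the ring on the aromatic carbon between two ring nitrogen atoms proves highly sensitive to change: putting 2,4-dichlorophenyl in place of 4-methoxyphenyl gives a number 42.8 percentage points higher from compound 1 to compound 4 (beyond the scatter), a large weakening of the effect at the tested concentration. The earlier compounds shown here showed only a modest step on a different core, where a methoxy group gave way to hydrogen, and they said nothing about this position on the core of compound 1. Nothing available here explains why this swap weakens the effect so strongly.

On these data alone, whether the weakening follows the loss of the methoxy group or the arrival of the two chlorines remains open, and a plain phenyl or a 4-chlorophenyl at this position would separate the two. Also open, as far as these compounds go, is how an amine or a carboxylic acid on this ring would behave.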